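Chloro removal on the pendant aryl: benzyl versus thiourea

A few compounds are considered here, and "the series" means these few. Any claim that something is new, unique, unknown or untested is made for them only; others in the source may bear on it.

Compound 1 `NC(=O)c1c(NC(=O)c2ccccc2Cl)sc2c1CCN(Cc1ccccc1)C2` and compound 2 `NC(=O)c1c(NC(=O)c2ccccc2Cl)sc2c1CCN(Cc1ccccc1Cl)C2` share one core and differ only on the group attached to the ring nitrogen. In a functional assay on HL-60 cells (Homo sapiens) for antiproliferative activity, with a stated time of 24 h (on this read-out lower numbers stand for stronger inhibition and higher numbers for weaker inhibition), compound 1 gives 12000 nM, while compound 2 gives 2900 nM. The change hydrogen in place of chloro on an aromatic carbon is thus a 4.1-fold higher number from compound 2 to compound 1 (0.62 log units; beyond the scatter). Compound 3 `NC(=O)c1c(NC(=O)c2ccccc2)sc2c1CCN(C(=S)Nc1ccccc1Cl)C2` differs from compound 2 in more than one place; the difference between the two cores is not broken down here. In this assay compound 3 gives 13800 nM, close to compound 1 and a higher number than compound 2. Compound 4 `NC(=O)c1c(NC(=O)c2ccccc2)sc2c1CCN(C(=S)Nc1ccccc1)C2` has not been measured yet; it differs from compound 3 by hydrogen in place of chloro on an aromatic carbon. This is the same kind of change as that from compound 2 to compound 1, though the surroundings differ: there the wider reading was 2-chlorobenzyl to benzyl, here it is (2-chlorophenyl)amino to anilino. Compound 4 is expected to show a 2.2-fold higher number from compound 3 to compound 4 (0.34 log units; beyond the scatter), a somewhat smaller step than the earlier one, because the earlier result a 4.1-fold higher number from compound 2 to compound 1 (0.62 log units; beyond the scatter) came on a benzyl rather than a thiourea arm. For compound 4 the estimated value is 30000 nM, expected to fall between 10000 nM and 80000 nM.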

Compound 4, half-maximal inhibitory concentration: > 50000 nM
Compound 4: a limit, no number; the forecaster's own chance of this, stated with the estimate: 25%; at least 1.6-fold (0.22 log units) between middle value and limit.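

Working notes on carrying the change. In this assay compound 4 gives > 50000 nM, which is a limit of the assay and not a number. Hydrogen in place of chloro on the aromatic carbon gives an at least 3.6-fold higher number from compound 3 to compound 4 (0.55 log units; beyond the scatter), so on the two cores shown, with no pair going against it, the change moves the number the same way, on the benzyl arm and on the thiourea arm alike: the same change on two cores in this assay, a 4.1-fold higher number (0.62 log units; beyond the scatter) from compound 2 to compound 1 and an at least 3.6-fold higher number (0.55 log units; beyond the scatter) from compound 3 to compound 4; the limit leaves it open whether they differ The direction therefore carries across these two pairs, but the size of the step on the thiourea arm stays unfixed, and two pairs do not make a rule for the series: the limit of > 50000 nM in this assay, at which 1 of the 4 values shown sits.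

Open, on these data alone, is whether fluoro, methyl or methoxy on the same aromatic carbon would follow the direction seen with chloro. Also open, as far as these compounds go, is whether the step depends on the arm on the ring nitrogen or on the other differences between the two cores.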